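Fluoro to Chloro, Repeated at a Second Ring Position

The source may hold more compounds than are shown below. What is called first, only, known or untested is meant among the compounds shown, and "the series" means these compounds.

Measured compounds:
compound 1 `O=C(CSc1nc(Nc2ccccc2)c2ccccc2n1)Nc1cccc(F)c1`: 15600 nM
compound 2 `O=C(CSc1nc(Nc2ccccc2)c2ccccc2n1)Nc1cccc(Cl)c1`: 12600 nM
compound 3 `C=CC(=O)Nc1cccc(NC(=O)CSc2nc(Nc3ccccc3F)c3ccccc3n2)c1`: 9340 nM

All three numbers come from a functional assay on PC-3 cells (Homo sapiens) for inhibition, read by MTT assay, with a stated time of 72 h; on this read-out higher numbers stand for weaker inhibition and lower numbers for stronger inhibition. Among the compounds with values here, the only step that can be counted among them is a 1.2-fold lower number from compound 1 to compound 2 (0.09 log units; within the scatter), a change of chloro in place of fluoro on an aromatic carbon. Compound 3 carries a different core; the difference between the cores of compound 1 and compound 3 is not broken down here, and its number stands within the scatter of both compound 1 and compound 2.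

Compound 4 `C=CC(=O)Nc1cccc(NC(=O)CSc2nc(Nc3ccccc3Cl)c3ccccc3n2)c1` is not yet measured. It differs from compound 3 by chloro in place of fluoro on an aromatic carbon. Within the data shown here, this is the same kind of change as the one from compound 1 to compound 2, but not the same: there the halogen sits meta to a large group, here ortho to a large group.

The step expected in this assay is a 1.1-fold lower number from compound 3 to compound 4 (0.06 log units; within the scatter), which rests on the earlier step of a 1.2-fold lower number from compound 1 to compound 2 (0.09 log units; within the scatter) being within the scatter. Compound 4 is therefore estimated at 8200 nM, with a likely range from 4000 nM to 17000 nM.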

Compound 4, half-maximal inhibitory concentration: 14400 nM
Beside the measured number, compound 4's estimate is 1.8-fold (0.24 log units) below it; low and high end bracket the measured number.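

In this assay, chloro in place of fluoro gave a 1.5-fold higher number from compound 3 to compound 4 (0.19 log units; within the scatter), so on this second core the change again left the number within the scatter. Set side by side, the two steps cannot be told apart: the same change on two cores in this assay, a 1.2-fold lower number (0.09 log units; within the scatter) from compound 1 to compound 2 and a 1.5-fold higher number (0.19 log units; within the scatter) from compound 3 to compound 4, 1.9-fold (0.28 log units) apart, within the scatter of two such steps. This shows that, in these two pairs, the change moved the number by no more than repeated measurements would, and that nothing separates its outcome on one core from its outcome on the other; it does not show that the change has no effect, that its effect is the same on both cores, or that the same would hold on any further core.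

Still open, as far as these compounds go, is whether a bromo, a methoxy or an amine in place of the halogen on the 2-chlorophenyl group of compound 4 would move the number beyond the scatter. Also open, from the compounds shown here alone, is whether a propanamide in place of the acrylamide of compound 4 would change its number at all.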